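This account rests on a few compounds, and the source may have more. Where it says the series, first, only, none or still open, it means among the compounds named here.

Of the compounds shown here, two have so far been read in an ADME assay on HEK293 cells (Homo sapiens) for cytotoxicity, read by MTT assay, with a stated time of 72 h; a lower number here means a stronger inhibitor, a higher number a weaker inhibitor. Compound 1 `COc1ccc(C2=C(c3cc(OC)c(OC)c(OC)c3)C(=O)CC2O[SiH2]C(C)(C)C)cc1` gives > 100 ug/mL, which is a limit of the assay and not a number. Compound 2 `COc1cc(C2=C(c3cc(C)c(OC)c(C)c3)C(O)CC2=O)cc(OC)c1OC` gives > 100 ug/mL, which is also a limit and not a number. Within the data shown here, compound 2 therefore has no exact place on the scale, and the series so far stands at the limit of > 100 ug/mL in this assay, at which 2 of the 2 values shown sit.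

Compound 3 `COc1cc(C2=C(c3cc(C)c(OC)c(C)c3)C(OC(C)=O)CC2=O)cc(OC)c1OC` differs from compound 2 by a single change, hydroxy to acetoxy, with acetyl in place of hydrogen on an oxygen on a saturated carbon. Among the measured compounds shown here, no pair of measured compounds shows what such a change does in this assay, so the expectation has little to rest on. It starts from compound 2, whose reading of > 100 ug/mL is a limit. No shift beyond the usual scatter is expected, and the expected size of the change is a number no higher from compound 2 to compound 3 (the limit leaves the size open). For compound 3 the estimate is 100 ug/mL, with an expected range from 50 ug/mL to 200 ug/mL.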

Compound 3, half-maximal inhibitory concentration: > 100 ug/mL
Compound 3: only a limit was reported; the forecaster's own chance of this, stated with the estimate: 75%; the middle value sits exactly at the limit.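

Compound 2 and compound 3 are both reported only as limits of the assay, so no step can be read from compound 2 to compound 3. The compounds shown leave open whether acetyl in place of hydrogen on an oxygen on a saturated carbon changes the reading in this assay at all, and where any of them stands on the scale: the limit of > 100 ug/mL in this assay, at which 3 of the 3 values shown sit.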